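Chalcone notes: methoxy to isopropoxy on the bromo compound

The source may report more compounds than this note shows. Statements on the series, on what has been measured and on what is new or still open speak of the compounds shown alone.

Measured in a functional assay on LNCaP cells (Homo sapiens) for antiproliferative activity, with stated times of 2 days and 4 days; on this read-out lower numbers stand for stronger inhibition and higher numbers for weaker inhibition
- Compound 1 `COc1ccc(O)c(C(=O)/C=C/c2ccccc2OC)c1` gives 7250 nM
- Compound 2 `O=C(/C=C/c1ccccc1O)c1cc(Cl)ccc1O` gives 3520 nM
- Compound 3 `COc1ccccc1/C=C/C(=O)c1cc(Br)ccc1O` gives 4960 nM

Compound 3 at 4960 nM lies within the scatter of both compound 1 and compound 2. Compound 4 `CC(C)Oc1ccccc1/C=C/C(=O)c1cc(Br)ccc1O` differs from it by isopropyl in place of methyl on an oxygen on an aromatic ring. Going by the values given here, the single measured step of a 1.5-fold lower number from compound 1 to compound 3 (0.16 log units; within the scatter) stays within the scatter and is a different change, bromo in place of methoxy on an aromatic carbon. Among the compounds with values here, no measured step covers the change at hand. No step beyond the scatter is therefore expected in this assay, and no direction is favoured. The estimated step is a 1.0-fold lower number from compound 3 to compound 4 (0.01 log units; within the scatter) and no larger. Compound 4 is expected at 4800 nM with 2000 nM to 10000 nM as the estimated range.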

Compound 4, half-maximal inhibitory concentration: 4200 nM
Beside the measured number, compound 4's estimate is 1.1-fold (0.06 log units) above it; measured number inside the range.
By their numbers in this assay, from the lowest: compounds 2, 4, 3 and 1 (each within the scatter of the next, the first and the last beyond it).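

In this assay the step from methoxy to isopropoxy on the bromo compound is a 1.2-fold lower number from compound 3 to compound 4 (0.07 log units; within the scatter) and stays within the scatter. This is the first change shown at this oxygen on an aromatic ring, and the larger isopropyl group is taken there with no step beyond the scatter. Nothing on hand bears on the reason for this result.

As far as these compounds go, it remains open whether a longer chain ending in an amine or a carboxylic acid on this oxygen would give a step beyond the scatter. From the compounds shown here alone, whether isopropoxy gives the same result with chloro in place of bromo also remains open.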